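Series notes: from compound 1 to compound 4

The source may hold more compounds than are shown below. What is called first, only, known or untested is meant among the compounds shown, and "the series" means these compounds.

Measured so far:
- compound 1 `ONc1cccc(CNc2cc(Br)cc3[nH]ncc23)c1`: "not active" (no number reported)
- compound 2 `Oc1ccc(CNc2cc(Br)cc3[nH]ncc23)cc1F`: 26%
- compound 3 `Brc1cc(NCc2cccc3sccc23)c2cn[nH]c2c1`: 56%

In an assay for inhibition of Tryptophan 2,3-dioxygenase (Homo sapiens), with a stated time of 1 h, tested at 10 uM (a higher number here means more inhibition at the concentration tested (going by the name of the read-out), a lower number less inhibition), compound 1 is reported as "not active" (no number reported), so no single number places it; it stands below the numbers of compound 2 and compound 3 only in the sense that none was reported for it. Compound 2 gives 26% and compound 3 gives 56% in this assay.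

Compound 4 `O=C1CCCC(Nc2cccc(CNc3cc(Br)cc4[nH]ncc34)c2)C1` differs from compound 1 by 3-oxocyclohexyl in place of hydroxy on a nitrogen on an aromatic ring, the hydroxyamino becoming (3-oxocyclohexyl)amino. Among the measured compounds shown here, no measured pair shows this kind of change, so its size is unknown; the larger group is expected to lift the read-out modestly, beyond the scatter, though no measured value supports this directly. For compound 4 the estimate in this assay is 25%, with a range from 0% to 55%.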

Compound 4, a percentage reported as inhibition, at one concentration (the size of the read-out at that concentration, not a potency): 46%
Estimate against measurement, compound 4: 21 percentage points below; low and high end bracket the measured number.
By their numbers in this assay, from the lowest: compound 2; then compounds 4 and 3 (each within the scatter of the next).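

Among the compounds shown here, with compound 1 at "not active" (no number reported) in this assay and so without a number, no step to compound 4 can be read. On these data alone, what the 3-oxocyclohexyl group itself contributes to the read-out of compound 4 stays open. No evidence bearing on this result is at hand.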